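The source may hold more compounds than are shown below. What is called first, only, known or untested is meant among the compounds shown, and "the series" means these compounds.

The series shares one core, carried through from compound 1 `CCCSc1nc(N/N=C/c2cccs2)c2nnn(Cc3ccccc3)c2n1` to compound 2 `CCCSc1nc(N/N=C/c2c[nH]c3ccccc23)c2nnn(Cc3ccccc3)c2n1` and compound 3 `CCCSc1nc(N/N=C/c2ccc(Br)cc2)c2nnn(Cc3ccccc3)c2n1`; the three differ only in the aryl group on the carbon with a double bond to nitrogen. In a functional assay on ECa-109 cells (Homo sapiens) for antiproliferative activity, read by MTT assay, with a stated time of 72 h (on this read-out higher numbers stand for weaker inhibition and lower numbers for stronger inhibition), compound 1 gives > 64000 nM, which is a limit of the assay rather than a number. Compound 2 gives 8690 nM in this assay. Compound 3 likewise reaches only a limit, > 64000 nM. The step of an at least 7.3-fold lower number from compound 1 to compound 2 (0.86 log units; beyond the scatter) is readable, as is an at least 7.3-fold higher number from compound 2 to compound 3 (0.86 log units; beyond the scatter), while a step that the two limits leave unreadable from compound 1 to compound 3 cannot be sized, two of the three values sitting at the limit of > 64000 nM in this assay, at which 2 of the 3 values shown sit. Compound 3 thus stands at the limit, and no number is known for it.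

Compound 4 `CCCSc1nc(N/N=C/c2ccc([N+](=O)[O-])cc2)c2nnn(Cc3ccccc3)c2n1` differs from compound 3 by nitro in place of bromo on an aromatic carbon. Within the data shown here, none of the measured steps changes a substituent on a six-membered aromatic ring of carbon only; each swaps the whole aryl group, so none bears directly on this change. Only the 1H-indol-3-yl group of compound 2 gave a number, the thiophen-2-yl and 4-bromophenyl groups both sitting at the limit. Among the measured compounds shown here, with no step to lean on, the estimated step is an at least 1.2-fold lower number from compound 3 to compound 4 (0.10 log units; that floor lies within the scatter), with a fair chance that only a limit is reported. Compound 4 is expected at 50000 nM, within a range of 10000 nM to 200000 nM.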

Compound 4, half-maximal inhibitory concentration: 6640 nM
Estimate against measurement, compound 4: 7.5-fold (0.88 log units) above; measured number below the stated range.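

Exchanging bromo for nitro on an aromatic carbon para to a large group gives an at least 9.6-fold lower number from compound 3 to compound 4 (0.98 log units; beyond the scatter) in this assay, the only step shown that changes a substituent rather than the whole aryl group, and it shows that this position responds to such a change. The 1H-indol-3-yl group is also not alone in giving a number, since replacing it with the 4-nitrophenyl group gives a 1.3-fold lower number from compound 2 to compound 4 (0.12 log units; within the scatter), which leaves the two groups indistinguishable in this assay. Replacing the thiophen-2-yl group with the 4-nitrophenyl group gives an at least 9.6-fold lower number from compound 1 to compound 4 (0.98 log units; beyond the scatter), so the four compounds divide into compound 2 and compound 4, which give numbers, and compound 1 and compound 3, which do not.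

The full size of the steps from compound 1 and compound 3 stays open because each starts from a limit rather than a number: the limit of > 64000 nM in this assay, at which 2 of the 4 values shown sit. The compounds shown also leave open whether the response is particular to nitro, as they do not tell how an amine, a nitrile or a carboxylic acid on the same aromatic carbon would read.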